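Trifluoromethyl to ethoxycarbonyl: an expected step in binding

The compounds below may be only part of what the source reports. "The series", "measured", "known", "first", "only" and "open" are said of these compounds alone.

Measured compounds:
compound 1 `CC/N=C(\N)Nc1ccc(Sc2ccc(OC)cc2)cc1` with 251 nM
compound 2 `FC(F)(F)c1ccc(Sc2ccc(NC3=NCCN3)cc2)cc1` with 50.1 nM

The two compounds were tested in an assay (Rattus norvegicus) for binding affinity to prostacyclin receptor (Homo sapiens), read by radioligand binding; on this read-out lower numbers stand for stronger inhibition and higher numbers for weaker inhibition. Compound 1 gives 251 nM, while compound 2 gives 50.1 nM. Of the two numbers, compound 2 has the lower one, and the gap to compound 1 lies beyond the scatter of repeated measurements, so compound 2 is the tighter binder of the pair.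

Compound 3 `CCOC(=O)c1ccc(Sc2ccc(NC3=NCCN3)cc2)cc1` has not yet been measured. It differs from compound 2 in one place: ethoxycarbonyl in place of trifluoromethyl on an aromatic carbon. Among the compounds measured so far there is no pair that differs in just this way, so the size of this step cannot be read from existing numbers. Both compounds keep the same core and the same attachment of the imidazoline-bearing side; only the group on the far ring is exchanged.

Going by the values given here, with no precedent among the measured pairs, compound 3 is expected to bind somewhat more weakly than compound 2, by a step of a 2.2-fold higher number from compound 2 to compound 3 (0.34 log units; beyond the scatter), though a change within the scatter cannot be excluded. The estimated value for compound 3 is 110 nM, with a plausible range from 35 nM to 400 nM.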

Compound 3, inhibition constant: 50.1 nM
Beside the measured number, compound 3's estimate is 2.2-fold (0.34 log units) above it, within the range that was stated.
By their numbers in this assay, from the lowest: compounds 2 and 3 (each within the scatter of the next); then compound 1.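

In this assay, putting ethoxycarbonyl in place of trifluoromethyl on this aromatic carbon gives no change at the digits printed from compound 2 to compound 3 (within the scatter). The earlier compounds shown here could not show this, since no measured pair differed in this way: at this position, para to a large group, a group with 5 heavy atoms, a double bond outside aromatic rings and 2 hydrogen-bond acceptors reads the same as a group with 4 heavy atoms and 0 hydrogen-bond acceptors. Nothing available here explains why these two quite different groups give the same reading.

As far as these compounds go, what remains open is whether the position would give the same reading with a carboxylic acid or an amine in this place, or with a longer chain on the ester, such as butoxycarbonyl. From the compounds shown here alone, this is also a single pair on a single core, so it remains open whether the same exchange would leave the number unchanged if the other end of the molecule were different, as it is in compound 1.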